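From Compound 2 to Compound 3: Expected Cell Tolerance

The source may report more compounds than this note shows. Statements on the series, on what has been measured and on what is new or still open speak of the compounds shown alone.

Compound 1 `CCCOc1ccc2c(C)cc(=O)oc2c1CN1CCCCC1` was tested in an ADME assay on MT4 cells (Homo sapiens) for cytotoxicity, read by MTT assay, with a stated time of 96 h; a lower number here means that less compound is tolerated, a higher number that more compound is tolerated. For compound 1 the result is a limit of the assay, > 100000 nM. Among the compounds with values here, compound 2 `CCC(=O)Oc1[nH]c2ccccc2c1Cc1c(OC(C)=O)ccc2ccc(=O)oc12` gives 67000 nM in this assay; this is the only plain number measured so far. The other result, that of compound 1, is a limit of the assay (the limit of > 100000 nM in this assay, at which 1 of the 2 values shown sits). Compound 3 `CC(=O)Oc1ccc2ccc(=O)oc2c1Cc1c(-c2ccccc2)[nH]c2ccccc12` differs from compound 2 by a single exchange: phenyl in place of propanoyloxy on an aromatic carbon. Within the data shown here, no measured pair shows what such a change does here; the step of a 1.3-fold lower number from compound 2 to compound 3 (0.13 log units; within the scatter) is expected to stay within the usual scatter. Compound 3 is therefore estimated at 50000 nM, likely between 15000 nM and 100000 nM.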

Compound 3, half-maximal cytotoxic concentration: > 100000 nM
Compound 3: only a limit was reported (the forecaster's own chance of this, stated with the estimate: 30%); middle value at least 2.0-fold (0.30 log units) from the limit.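

Within the data shown here, this is the first measured step at this position: in this assay, phenyl in place of propanoyloxy on the aromatic carbon next to the ring nitrogen gives an at least 1.4-fold higher number from compound 2 to compound 3 (0.17 log units; that floor lies within the scatter), so this larger group brings no sign of lower tolerance. For compound 3 the result, > 100000 nM, is a limit of the assay and not a number. The true size of the step therefore cannot be read, and the top of the range is now shared: the limit of > 100000 nM in this assay, at which 2 of the 3 values shown sit.

Going by these compounds, what an amine or a carboxylic acid at this position would do remains open. So does whether any group here brings the number clearly down.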